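The compounds below may be only part of what the source reports. "The series", "measured", "known", "first", "only" and "open" are said of these compounds alone.

Measured compounds:
Compound 1 `O=C(Nc1cccc(-n2cc(-c3ccncc3)c(-c3ccc(Cl)c(O)c3)n2)c1)Nc1cccc(C(F)(F)F)c1` — in a functional assay on 786-0 cells (Homo sapiens) for inhibition, read by sulforhodamine B assay, with a stated time of 48 h (a higher number here means a weaker inhibitor of growth, a lower number a stronger inhibitor of growth), compound 1 gives > 32500 nM, which is a limit of the assay and not a number.
Compound 2 `O=C(Nc1cccc(-n2cc(-c3ccncc3)c(-c3ccc(Cl)c(O)c3)n2)c1)Nc1ccc(Cl)c(Cl)c1` — in this assay compound 2 gives > 32500 nM, likewise a limit.

Within the data shown here, compound 1 thus stands at the limit of this assay, as does the only other measured compound, a picture summed up by the limit of > 32500 nM in this assay, at which 2 of the 2 values shown sit. Among the measured compounds shown here, the single measured step, a step that the two limits leave unreadable from compound 1 to compound 2, is unreadable, both of its ends being limits. Compound 3 `O=C(Nc1cccc(-n2cc(-c3ccncc3)c(-c3ccc(Cl)c(O)c3)n2)c1)Nc1cc(C(F)(F)F)cc(C(F)(F)F)c1` differs from compound 1 by trifluoromethyl in place of hydrogen on an aromatic carbon. The measured step bears on this change only in that a second variation of the same aryl urea partner left the value at the limit, so no direction or size beyond the scatter can be read from it. Compound 3 is therefore expected to sit again at the limit, estimated at 45000 nM. For compound 3 the expected range runs from 12000 nM to 150000 nM. The implied step that the limit leaves unreadable from compound 1 to compound 3 is expected to stay within the scatter.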

Compound 3, concentration for total growth inhibition: 3160 nM
Estimate against measurement, compound 3: 14-fold (1.15 log units) above; measured number below the stated range.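

Trifluoromethyl in place of hydrogen on an aromatic carbon of the aryl urea partner, meta to a trifluoromethyl group, gives in this assay an at least 10-fold lower number from compound 1 to compound 3 (1.01 log units; beyond the scatter). This step is beyond the scatter, so this carbon is a place where a single change on the shared core moves the read-out, which the earlier pair could not show. Compound 3 is the only compound shown with a number, and the other two values are limits of the assay: the limit of > 32500 nM in this assay, at which 2 of the 3 values shown sit.

As far as these compounds go, the true size of the step stays open, as compound 1 is known only by a limit. Also open, from the compounds shown here alone, is whether the gain belongs to trifluoromethyl itself, or whether chlorine, a nitrile or a methoxy group on the same carbon would move the value in the same way.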